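A few compounds are considered here, and "the series" means these few. Any claim that something is new, unique, unknown or untested is made for them only; others in the source may bear on it.

Measured so far in an assay on isolated protein for binding affinity to metabotropic glutamate receptor 2 (Homo sapiens); on this read-out lower numbers stand for an effect already at smaller amounts and higher numbers for an effect only at larger amounts of compound:
- compound 1 `CC1(C2CCCC2)Cc2cc(OCC(=O)Nc3ccc(-c4nn[nH]n4)cc3)c(Cl)c(Cl)c2C1=O`: 600 nM
- compound 2 `CC1(C2CCCC2)Cc2cc(OCCCc3nn[nH]n3)c(Cl)c(Cl)c2C1=O`: 5000 nM

Compound 2 stands at the highest of the two numbers; compound 1 gives the lower number, and the gap between the two lies beyond the scatter. The two structures differ in more than one place, so no single step can be read from that pair.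

Compound 3 `CC1(C2CCCC2)Cc2cc(OCCCCCc3nn[nH]n3)c(Cl)c(Cl)c2C1=O` is the next candidate and is not yet measured. It differs from compound 2 in one place: 2-(2H-tetrazol-5-yl)ethyl in place of 2H-tetrazol-5-yl on a saturated chain carbon, three bonds along the chain from an oxygen on an aromatic ring, that is, the chain between the aromatic oxygen and the tetrazole grows by two saturated carbons.

Going by the values given here, no measured pair shows what such a chain lengthening does here. The step from compound 2 to compound 3 is expected to be small, a 1.7-fold lower number from compound 2 to compound 3 (0.22 log units; within the scatter), towards a slightly lower number but not clearly beyond the scatter. Compound 3 is estimated at 3000 nM, with a range from 800 nM to 12000 nM.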

Compound 3, half-maximal effective concentration: 761 nM
Beside the measured number, compound 3's estimate is 3.9-fold (0.60 log units) above it; measured number outside the range, below it.
By their numbers in this assay, from the lowest: compounds 1 and 3 (each within the scatter of the next); then compound 2.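

In this assay, going by these compounds alone, this position on the saturated chain responds to chain length: 2-(2H-tetrazol-5-yl)ethyl in place of 2H-tetrazol-5-yl gives a 6.6-fold lower number from compound 2 to compound 3 (0.82 log units; beyond the scatter) and is the first change in a single place that can be read. The tetrazole stays the same in the counted donors and acceptors, and the chain grows by two saturated carbons, so the step is tied to that lengthening alone. Nothing measured here bears on the reason for this step.

Open, from the compounds shown here alone, is whether a still longer chain on the core of compound 3 continues this trend, holds the number or reverses it. Also open, going by these compounds, is what a carboxylic acid in place of the tetrazole at the chain end of compound 3 would give.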